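Anilide in place of piperazine on the shared core

The source may hold more compounds than are shown below. What is called first, only, known or untested is meant among the compounds shown, and "the series" means these compounds.

Compound 1 `N#CC1(NC(=O)[C@@H]2C[C@@H](S(=O)(=O)c3ccccc3)C[C@H]2C(=O)N2CC3CCC(C2)O3)CC1`: 1 nM
Compound 2 `N#CC1(NC(=O)[C@@H]2C[C@@H](S(=O)(=O)c3ccccc3)C[C@H]2C(=O)N2CCNCC2)CC1`: 11 nM

In an assay on isolated protein for inhibition of cathepsin S (Homo sapiens), read by fluorescence, with a stated time of 20 min (on this read-out lower numbers stand for stronger inhibition and higher numbers for weaker inhibition), compound 2 stands highest of the two numbers; its nearest neighbour, compound 1, gives 1 nM. Compound 3 `N#CC1(NC(=O)[C@@H]2C[C@@H](S(=O)(=O)c3ccccc3)C[C@H]2C(=O)Nc2ccc(F)cc2)CC1` carries (4-fluorophenyl)amino in place of piperazin-1-yl on a carbonyl carbon. Within the data shown here, the one step that touches this carbonyl carbon, an 11-fold higher number from compound 1 to compound 2 (1.04 log units; beyond the scatter), shows that the group on it moves the number well beyond the scatter. On that basis compound 3 is expected to move back toward the lower number, by a 2.2-fold lower number from compound 2 to compound 3 (0.34 log units; beyond the scatter). The estimate for compound 3 in this assay is 5 nM, between 1 nM and 25 nM.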

Compound 3, half-maximal inhibitory concentration: 26 nM
Estimate against measurement, compound 3: 5.2-fold (0.72 log units) below; measured number above the stated range.
By their numbers in this assay, from the lowest: compound 1; then compound 2; then compound 3.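

In this assay the step of a 2.4-fold higher number from compound 2 to compound 3 (0.37 log units; beyond the scatter) is modest and the step of a 26-fold higher number from compound 1 to compound 3 (1.41 log units; beyond the scatter) is large, so (4-fluorophenyl)amino on this carbonyl carbon does not restore the lower number of compound 1. With piperazin-1-yl and (4-fluorophenyl)amino both giving higher numbers, the group of compound 1 stands apart among the three, even though compound 3 carries the same count of heavy atoms. No measurement offered here explains why these groups differ. On these data alone, what stays open is whether the fluorine contributes to the number of compound 3, and whether a morpholine on this carbonyl carbon would come closer to compound 1.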